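This account rests on a few compounds, and the source may have more. Where it says the series, first, only, none or still open, it means among the compounds named here.

Working notes on the series, values in a functional assay on K562 cells (Homo sapiens) for antiproliferative activity, read by MTT assay, with a stated time of 5 days; a higher number here means a weaker inhibitor, a lower number a stronger inhibitor:

- compound 1 `COc1ccc(C=C(C(=O)c2cc(OC)c(OC)c(OC)c2)c2ccccc2O)cc1` gives 240000 nM
- compound 2 `COc1ccc(/C=C(/C(=O)c2cc(OC)c(OC)c(OC)c2)c2ccccc2O)cc1` gives 370000 nM
- compound 3 `COc1ccc(C=C(C(=O)c2cc(OC)c(OC)c(OC)c2)c2ccc(C)cc2)cc1[N+](=O)[O-]` gives 2430000 nM

Compound 1 sits with compound 2 at the low end of these numbers. The two lie within the scatter of each other, and compound 3 stands clearly higher than either.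

The next compound is compound 4 `COc1ccc(C=C(C(=O)c2cc(OC)c(OC)c(OC)c2)c2ccccc2O)cc1O`. The change from compound 1 is hydroxy in place of hydrogen on an aromatic carbon. In words, hydroxy takes the place of hydrogen on an aromatic carbon, ortho to a methoxy group, so that 4-methoxyphenyl becomes 3-hydroxy-4-methoxyphenyl.

Little of the measured data bears on this change. Going by the values given here, the only single-place step available is a 1.5-fold higher number from compound 1 to compound 2 (0.19 log units; within the scatter). It is small and concerns only the drawn configuration (the fact that one of compounds 1 and 2 is drawn with a defined configuration and the other without, at the place where they differ), not a substituent on an aromatic ring. Among the compounds with values here, no measured step adds or removes a hydroxy group on this ring, so neither the direction nor the size of the effect in this assay can be read from the series. The working expectation is therefore no step beyond the scatter, held with a wide margin on both sides.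

The expected step is a 1.2-fold lower number from compound 1 to compound 4 (0.08 log units; within the scatter).

For compound 4 the estimated value is 200000 nM, with an expected range from 30000 nM to 700000 nM.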

Compound 4, half-maximal inhibitory concentration: 35000 nM
Beside the measured number, compound 4's estimate is 5.7-fold (0.76 log units) above it, within the range that was stated.
By their numbers in this assay, from the lowest: compound 4; then compounds 1 and 2 (each within the scatter of the next); then compound 3.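

In this assay, going by these compounds alone, the change from 4-methoxyphenyl to 3-hydroxy-4-methoxyphenyl gives a 6.9-fold lower number from compound 1 to compound 4 (0.84 log units; beyond the scatter) and is the first single-place step that lies beyond the scatter. Within the data shown here, this position, ortho to a methoxy group, is therefore one where a substitution moves the number, and hydroxy in place of hydrogen moves it downward, whereas the only earlier single-place step concerned a drawn configuration and stayed within the scatter. Nothing measured in the series explains why this change has this effect.

This single step, taken on one core with the double bond drawn without a configuration, leaves open whether hydroxy itself matters at this position or whether an amine or a fluorine atom placed there would give a similar number. It also leaves open whether the step holds in the E form drawn for compound 2, and whether it carries over to a core with the 4-methylphenyl and nitro groups of compound 3.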